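Nitroanilide Variation and the Expected Potency of Compound 3

The source may report more compounds than this note shows. Statements on the series, on what has been measured and on what is new or still open speak of the compounds shown alone.

Measured compounds:
compound 1, `CCn1cc(C(=O)Nc2ccccc2O)c(=O)c2cc(F)c(N3CCNC(C)C3)c(F)c21`: > 50000 nM
compound 2, `CCn1cc(C(=O)Nc2ccc(C)c([N+](=O)[O-])c2)c(=O)c2cc(F)c(N3CCNC(C)C3)c(F)c21`: 29100 nM

Of the compounds shown here, two have been tested in a functional assay on Bel-7402 cells (Homo sapiens) for cytotoxicity, read by MTT assay; a higher number here means a weaker inhibitor, a lower number a stronger inhibitor. In this assay compound 1 gives > 50000 nM, which is a limit of the assay and not a number. In this assay compound 2 gives 29100 nM, the only plain number shown, so compound 2 stands as the single quantified point of the set. Within the data shown here, the one measured step, an at least 1.7-fold lower number from compound 1 to compound 2 (0.23 log units; that floor lies within the scatter), rests on the limit of > 50000 nM in this assay, at which 1 of the 2 values shown sits, and its floor lies within the scatter, so it shows no change that can be counted on.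

Compound 3, `CCn1cc(C(=O)Nc2cc([N+](=O)[O-])ccc2F)c(=O)c2cc(F)c(N3CCNC(C)C3)c(F)c21`, differs from compound 2 by 2-fluoro-5-nitrophenyl in place of 4-methyl-3-nitrophenyl on an amide-type nitrogen. Among the measured compounds shown here, no measured step concerns an exchange of one nitrophenyl for another on this amide nitrogen; the only comparison available, from the hydroxyphenyl to the nitrophenyl anilide, did not rise beyond the scatter. The expected step is therefore none beyond the scatter, a 1.0-fold higher number from compound 2 to compound 3 (0.01 log units; within the scatter). Compound 3 is estimated at 30000 nM in this assay, with a range from 10000 nM to 100000 nM.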

Compound 3, half-maximal inhibitory concentration: 2900 nM
Compound 3: the middle estimate sits 10-fold (1.01 log units) above what was measured; measured number below the stated range.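

In this assay, exchanging 4-methyl-3-nitrophenyl for 2-fluoro-5-nitrophenyl on the amide-type nitrogen gives a 10-fold lower number from compound 2 to compound 3 (1.00 log units; beyond the scatter). This shows that the position responds to a change from one nitrophenyl group to another, which the earlier comparison of a hydroxyphenyl with a nitrophenyl anilide could not show. Set against the hydroxyphenyl anilide, the new group gives an at least 17-fold lower number from compound 1 to compound 3 (1.23 log units; beyond the scatter), a step that, unlike the earlier one, clears the scatter, although its size is only a floor, since compound 1 carries a limit of the assay and not a number: the limit of > 50000 nM in this assay, at which 1 of the 3 values shown sits.

The exchange from compound 2 to compound 3 removes the methyl group, brings in the fluorine and alters the place of the nitro group all in one step, and the compounds shown cannot separate these parts from one another. They also leave open whether the nitro group is needed at all, and whether an aminophenyl or carboxyphenyl group on this nitrogen would keep, lose or improve on the level reached by compound 3.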